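A few compounds are considered here, and "the series" means these few. Any claim that something is new, unique, unknown or untested is made for them only; others in the source may bear on it.

Three compounds of the series have been run in a functional assay on SW480 cells (Homo sapiens) for antiproliferative activity, read by MTT assay, with a stated time of 72 h; on this read-out lower numbers stand for stronger inhibition and higher numbers for weaker inhibition. Compound 1 `O=c1c(CSC(=S)N2CCCC2)coc2ccccc12` gives 2300 nM, the lowest of the three numbers. Compound 2 `Cc1ccc2c(=O)c(CSC(=S)N3CCCC3)coc2c1` gives 5900 nM and compound 3 `COc1ccc2occ(CSC(=S)N3CCCC3)c(=O)c2c1` gives 4800 nM; the two steps, a 2.6-fold higher number from compound 1 to compound 2 (0.41 log units; beyond the scatter) and a 2.1-fold higher number from compound 1 to compound 3 (0.32 log units; beyond the scatter), both lie beyond the scatter and both run toward weaker inhibition, each from a single substituent added on an aromatic carbon of the shared core. Compound 4 `CC(C)N(C(=S)SCc1coc2ccccc2c1=O)C(C)C` differs from compound 1 at a different place: diisopropylamino in place of pyrrolidin-1-yl on a thiocarbonyl carbon. Among the measured compounds shown here, neither measured step touches the thiocarbonyl carbon or the amine on it, so no measured step bears directly on this change; the two steps in hand show only that single-group changes elsewhere on compound 1 moved this assay by modest amounts. The expected step here is a 1.1-fold higher number from compound 1 to compound 4 (0.04 log units; within the scatter), nothing beyond the scatter, with a wide allowance on either side. Compound 4 is accordingly estimated at 2500 nM, with a range from 800 nM to 8000 nM.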

Compound 4, half-maximal inhibitory concentration: 6800 nM
Compound 4: middle estimate off by 2.7-fold (0.43 log units), on the low side; low and high end bracket the measured number.
By their numbers in this assay, from the lowest: compound 1; then compounds 3, 2 and 4 (each within the scatter of the next).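

The amine on the thiocarbonyl carbon responds in this assay: diisopropylamino in place of pyrrolidin-1-yl gives a 3.0-fold higher number from compound 1 to compound 4 (0.47 log units; beyond the scatter) and so moves the series modestly toward weaker inhibition at a place the steps on aromatic carbons could not address. Compound 1 now lies beyond the scatter from each of the other three compounds, and so holds the lowest number of the four. This single change replaces a ring with an open-chain amine and also alters the heavy-atom count, and the data on hand offer no explanation for the step.

The compounds shown leave open whether the ring or the size of the amine tracks with this step. A piperidin-1-yl or a diethylamino group on the thiocarbonyl carbon would help separate the two.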